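The source may report more compounds than this note shows. Statements on the series, on what has been measured and on what is new or still open speak of the compounds shown alone.

Measured so far in a functional assay on HCT-116 cells (Homo sapiens); a higher number here means a weaker inhibitor of growth, a lower number a stronger inhibitor of growth

- compound 1 `Oc1cc(-c2ccc(Cl)cc2)nc2ncccc12` gives 32400 nM
- compound 2 `COc1cccc(-c2cc(O)c3c(C)cc(C)nc3n2)c1` gives 407 nM
- compound 3 `COc1cccc(-c2cc(O)c3cc(C)cnc3n2)c1` gives 22.4 nM

Of these three, compound 3 has the lowest number, and the gaps up to compound 2 and compound 1 both lie beyond the scatter. Compound 4 `COc1cccc(-c2cc(O)c3cccnc3n2)c1` is still unmeasured. It differs from compound 3 in one place (hydrogen in place of methyl on an aromatic carbon), with hydrogen in place of methyl on an aromatic carbon. Among the compounds with values here, no measured pair shows this change alone, so its size is uncertain. A moderate rise in the number is expected because compound 3 stands at 22.4 nM as the lowest of the three. The estimated step is a 3.6-fold higher number from compound 3 to compound 4 (0.55 log units; beyond the scatter) and would lie beyond the scatter. For compound 4 the estimate is 80 nM with an expected range from 20 nM to 400 nM in this assay.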

Compound 4, concentration for 50% growth inhibition: 36.3 nM
Estimate against measurement, compound 4: 2.2-fold (0.34 log units) above; the measured number falls inside the stated range.
By their numbers in this assay, from the lowest: compounds 3 and 4 (each within the scatter of the next); then compound 2; then compound 1.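

In this assay the change of hydrogen in place of methyl on an aromatic carbon can now be read alone, and it gives a 1.6-fold higher number from compound 3 to compound 4 (0.21 log units; within the scatter), within the scatter. At this position, two atoms from the ring nitrogen, the methyl can therefore be lost without a change that can be told from scatter. No measurement shown here accounts for this result. Going by these compounds, whether a longer chain such as ethyl, or an amine, would be tolerated on this carbon remains open. So does whether the same change elsewhere on this ring would be as small.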